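Swapping a pyridyl ether for a hydroxyphenyl ether

This account rests on a few compounds, and the source may have more. Where it says the series, first, only, none or still open, it means among the compounds named here.

Compound 1 `O=c1cc(-n2cc(-c3ccccc3)nn2)c2cc(Br)ccc2o1`: 9450 nM
Compound 2 `O=c1cc(-n2cc(CSc3ccccc3)nn2)c2cc(Br)ccc2o1`: 36800 nM
Compound 3 `O=c1cc(-n2cc(COc3cccnc3)nn2)c2cc(Br)ccc2o1`: 39800 nM

All three compounds share one core and differ only in the group carried on the aromatic carbon of the five-membered ring. In a functional assay on MCF7 cells (Homo sapiens) for antiproliferative activity, read by MTT assay, with a stated time of 48 h (on this read-out higher numbers stand for weaker inhibition and lower numbers for stronger inhibition), compound 1 gives 9450 nM, the lowest of the three numbers. Compound 2, with (phenylsulfanyl)methyl in place of phenyl, gives 36800 nM, and the change is a 3.9-fold higher number from compound 1 to compound 2 (0.59 log units; beyond the scatter). Compound 3 gives 39800 nM; the step of a 4.2-fold higher number from compound 1 to compound 3 (0.62 log units; beyond the scatter) is of the same size, while the step of a 1.1-fold higher number from compound 2 to compound 3 (0.03 log units; within the scatter) is within the scatter. Compound 3 thus sits at the upper end of the range, set apart from compound 1 but not from compound 2.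

Compound 4 `O=c1cc(-n2cc(COc3ccccc3O)nn2)c2cc(Br)ccc2o1` keeps the linking oxygen and saturated carbon of compound 3 and changes only the ring on the oxygen: 2-hydroxyphenyl in place of pyridin-3-yl on an oxygen on a saturated carbon. Among the measured compounds shown here, the one measured step that bears on this kind of change, the exchange of the group on the chain carbon between compound 2 and compound 3, was within the scatter. For the measured compounds named here, no measured step tests a hydroxyl on that ring. Compound 4 is therefore expected to land close to compound 3, with a 1.3-fold lower number from compound 3 to compound 4 (0.12 log units; within the scatter) expected to stay within the scatter, perhaps leaning toward a slightly lower number. The estimate for compound 4 is 30000 nM, with a range from 12000 nM to 75000 nM.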

Compound 4, half-maximal inhibitory concentration: 24800 nM
Estimate against measurement, compound 4: 1.2-fold (0.08 log units) above, and the stated range covers the measured number.
By their numbers in this assay, from the lowest: compound 1; then compounds 4, 2 and 3 (each within the scatter of the next).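

Compound 4 shows that the ring on the oxygen can change from pyridin-3-yl to 2-hydroxyphenyl, which brings in a hydrogen-bond donor and loses the ring nitrogen, without any step beyond the scatter in this assay (a 1.6-fold lower number from compound 3 to compound 4 (0.21 log units; within the scatter)). The exchange of the whole group on the saturated chain carbon reads the same way (a 1.5-fold lower number from compound 2 to compound 4 (0.17 log units; within the scatter)), so phenylsulfanyl, (pyridin-3-yl)oxy and 2-hydroxyphenoxy now form a set of three that this read-out does not separate, and no compound among these three goes against that. Compound 1, with phenyl directly on the aromatic carbon, still gives the lowest number of the four at 9450 nM, and the hydroxyl has not brought compound 4 out of the group of the other two. Nothing at hand explains why these three groups read alike.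

It remains open whether the hydroxyl contributes anything at all, since a plain phenoxy group is not among the compounds shown. Also open, from the compounds shown here alone, is whether an amine or a carboxylic acid on that ring, or a longer chain in place of the saturated carbon, would move the number away from this group.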